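Moving a Methoxy Group on an Inactive Compound

A few compounds are considered here, and "the series" means these few. Any claim that something is new, unique, unknown or untested is made for them only; others in the source may bear on it.

So far, three compounds have been tested in a functional assay on MCF7 cells (Homo sapiens) for antiproliferative activity, read by MTT assay, with a stated time of 72 h; a lower number here means a stronger inhibitor, a higher number a weaker inhibitor. Compound 1 `COc1cccc(N2C(=O)COc3ccc(-c4cnc(Cl)c(NS(=O)(=O)c5ccc(F)cc5)c4)cc32)c1` reaches only the limit of the measurement, > 40000 nM, so no number is known for it. Compound 2 `O=C1COc2ccc(-c3ccc(O)cc3)cc2N1` likewise returns only the limit, > 40000 nM. Compound 3 `O=C1COc2ccc(-c3cccc(NS(=O)(=O)c4ccc(F)cc4)c3)cc2N1c1ccc(F)cc1` also stops at the limit, > 40000 nM. Compound 1 therefore stands among values that all sit at the same limit, (the limit of > 40000 nM in this assay, at which 3 of the 3 values shown sit), and none of the three can be ranked against another.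

Compound 4 `COc1ccc(N2C(=O)COc3ccc(-c4cnc(Cl)c(NS(=O)(=O)c5ccc(F)cc5)c4)cc32)cc1` has not yet been measured. It differs from compound 1 in one place only: 4-methoxyphenyl in place of 3-methoxyphenyl on an amide-type nitrogen in a ring.

Among the compounds with values here, no step between two measured compounds is available, so the size of such a change in this assay cannot be read from these data. Because compound 1 gives only the limit > 40000 nM, compound 4 is expected to stay at that limit too. The step of a number no higher from compound 1 to compound 4 (the limit leaves the size open) is expected to be none beyond the scatter. Compound 4 is estimated at 40000 nM, with a range from 20000 nM to 80000 nM.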

Compound 4, half-maximal inhibitory concentration: 36000 nM
The estimate for compound 4 lay 1.1-fold (0.05 log units) above the measured number; measured number inside the range.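

Within the data shown here, compound 4 gives the first true number in this assay, which shows that with 4-methoxyphenyl on the amide-type nitrogen in a ring, the value comes just within the range the assay can measure. The change from 3-methoxyphenyl gives an at least 1.1-fold lower number from compound 1 to compound 4 (0.04 log units; that floor lies within the scatter), so only a floor is known for this step, and its true size remains undetermined. Compound 4 is still the only compound here with a measured number, and the others give no value to compare it with: the limit of > 40000 nM in this assay, at which 3 of the 4 values shown sit.

As far as these compounds go, it remains open whether the position of the methoxy group on this phenyl ring truly matters in this assay, given that one member of the pair gives only a limit. It is also unknown how an amine or a carboxylic acid in place of the methoxy group would behave on the same ring.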